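This account rests on a few compounds, and the source may have more. Where it says the series, first, only, none or still open, it means among the compounds named here.

Measured in an ADME assay on L6 cells (Rattus norvegicus) for cytotoxicity; on this read-out lower numbers stand for stronger inhibition and higher numbers for weaker inhibition:
- Compound 1 `O=C(NN1Cc2ccccc2C1)c1ccccc1`: 68400 nM
- Compound 2 `Cn1[nH]c(=O)c2cc([N+](=O)[O-])ccc21`: > 517000 nM (a limit of the assay, not a number)
- Compound 3 `O=c1[nH]n(Cc2ccccc2F)c2ccc([N+](=O)[O-])cc12`: 210000 nM

Compound 2 has no exact reading, so it gives only a starting limit for any comparison: it stands at the limit of > 517000 nM in this assay, at which 1 of the 3 values shown sits. The question here is what happens on moving from compound 2 to compound 4 `O=c1[nH]n(-c2ccccc2)c2ccc([N+](=O)[O-])cc12`, which has not yet been measured in this assay. The structural change is phenyl in place of methyl on an aromatic nitrogen. Put simply, this is phenyl in place of methyl on an aromatic nitrogen.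

Within the data shown here, only one measured step bears on this change: an at least 2.4-fold lower number from compound 2 to compound 3 (0.39 log units; beyond the scatter). That step also brings an aromatic ring into the group on an aromatic nitrogen, although there the ring is 2-fluorophenyl on a saturated chain carbon rather than phenyl sitting directly on the nitrogen. It is therefore a rough guide, and one step alone cannot establish a pattern. Compound 1 has a different core and helps little here. A step of similar size toward a lower number seems the most reasonable expectation.

The expected change is an at least 2.3-fold lower number from compound 2 to compound 4 (0.37 log units; beyond the scatter). For compound 4 the estimated value is 220000 nM, with an expected range from 80000 nM to 500000 nM.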

Compound 4, half-maximal inhibitory concentration: 158000 nM
Compound 4: middle estimate off by 1.4-fold (0.14 log units), on the high side; measured number inside the range.
By their numbers in this assay, from the lowest: compound 1; then compounds 4 and 3 (each within the scatter of the next). At a limit, above all of these: compound 2.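

In this assay, phenyl in place of methyl on an aromatic nitrogen gives an at least 3.2-fold lower number from compound 2 to compound 4 (0.51 log units; beyond the scatter), so an aromatic ring sitting directly on this nitrogen moves the number in the same direction as the 2-fluorophenyl group carried on a saturated chain carbon in compound 3. Neither the chain carbon nor the fluorine is therefore needed for a move in this direction. Compound 3 at 210000 nM and compound 4 at 158000 nM lie within the scatter of each other. The true size of the step stays open-ended, since compound 2 has no exact reading, only a limit of the assay: the limit of > 517000 nM in this assay, at which 1 of the 4 values shown sits.

The compounds shown leave open whether an aromatic ring is needed at all on this nitrogen, or whether a longer chain with no ring, such as butyl, would give a similar number. They also leave open what an amine or a carboxylic acid on the phenyl ring of compound 4 would do to the number in this assay.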